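Methyl in place of isopropyl on a carbonate prodrug ester

A few compounds are considered here, and "the series" means these few. Any claim that something is new, unique, unknown or untested is made for them only; others in the source may bear on it.

Compound 1, `C[C@@H](O)[C@H]1C(=O)N2C(C(=O)OCOC(=O)C3CCCCC3)=C(S[C@@H]3CN[C@H](C(=O)Nc4cccc(C(=O)O)c4)C3)[C@H](C)[C@H]12`: in a physicochemical assay for metabolic stability, read by LC-MS, in phosphate buffer, with a stated time of 3 h, at pH 7.4, tested at 50 uM (a lower number here means that less of the compound is left, a higher number that more of the compound is left), compound 1 gives a limit of > 95%.
Compound 2, `CC(C)OC(=O)OCOC(=O)C1=C(S[C@@H]2CN[C@H](C(=O)Nc3cccc(C(=O)O)c3)C2)[C@H](C)[C@@H]2[C@@H]([C@@H](C)O)C(=O)N12`: in this assay compound 2 gives a limit of > 95%.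
Compound 3, `CC(C)OC(=O)C1=C(S[C@@H]2CN[C@H](C(=O)Nc3cccc(C(=O)OC(C)C)c3)C2)[C@H](C)[C@@H]2[C@@H]([C@@H](C)O)C(=O)N12`: in this assay compound 3 gives a limit of > 95%.

Compound 2 stands at the top limit of this assay, and so do the two other measured compounds, so no order among them can be drawn. Among the compounds with values here, the only measured step that touches compound 2 is a step that the two limits leave unreadable from compound 1 to compound 2, and its size stays hidden because both of its ends sit at the limit of > 95% in this assay, at which 3 of the 3 values shown sit. Compound 3 adds nothing further, since it too rests at that same limit.

Compound 4, `COC(=O)OCOC(=O)C1=C(S[C@@H]2CN[C@H](C(=O)Nc3cccc(C(=O)O)c3)C2)[C@H](C)[C@@H]2[C@@H]([C@@H](C)O)C(=O)N12`, differs from compound 2 by methyl in place of isopropyl on an oxygen next to a carbonyl group. Within the data shown here, the one measured step on the same carbonyl carbon left the read-out at its limit, so no step beyond the usual scatter is expected in this assay, in either direction. Compound 4 is therefore expected to remain at the limit as well, with an estimate of 96% and a range from 88% to 100%. The expected step is a step that the limit leaves unreadable from compound 2 to compound 4.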

Compound 4, percent of the compound remaining: > 95%
Compound 4 was reported as a limit (the forecaster's own chance of this, stated with the estimate: 80%); the middle value is on the limit's open side.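

Compound 4 rests at the same limit as compound 1 and compound 2, so neither of its steps can be read: the limit of > 95% in this assay, at which 4 of the 4 values shown sit.

The compounds shown leave open whether any of them truly differs from the others in this assay, with every value a limit and not a number.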